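Extending the Aminomethyl Chain: From Compound 2 to Compound 3

The source may report more compounds than this note shows. Statements on the series, on what has been measured and on what is new or still open speak of the compounds shown alone.

Measured so far in a functional assay on the whole organism with Mus musculus as the target; on this read-out lower numbers stand for an effect already at smaller amounts and higher numbers for an effect only at larger amounts of compound:
compound 1 `c1ccc(CNCc2nnc(-c3ccccc3-c3ccccc3)s2)cc1`: 29 mg/kg
compound 2 `NCc1nnc(-c2ccccc2-c2ccccc2)s1`: 22 mg/kg

Compound 2 and compound 1 share the same core and differ only at the amine nitrogen, where hydrogen replaces benzyl; on this assay this gave a 1.3-fold lower number from compound 1 to compound 2 (0.12 log units; within the scatter), so the two compounds lie within the scatter of each other and neither can be called the more potent.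

Compound 3 `NCCCc1nnc(-c2ccccc2-c2ccccc2)s1` carries 2-aminoethyl in place of amino on a saturated chain carbon bound to an aromatic carbon. For the measured compounds named here, the only measured step, a 1.3-fold lower number from compound 1 to compound 2 (0.12 log units; within the scatter), concerns the substituent on the amine and not the length of the chain that links it to the core, so no measured step bears directly on this change. With nothing to point either way, compound 3 is expected to stay close to compound 2, that is a 1.1-fold higher number from compound 2 to compound 3 (0.06 log units; within the scatter). The estimate for compound 3 on this assay is 25 mg/kg, within a range from 10 mg/kg to 60 mg/kg.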

Compound 3, dose for half-maximal effect: > 200 mg/kg
Compound 3: a limit, no number; the forecaster's own chance of this, stated with the estimate: 10%; at least 8.0-fold (0.90 log units) between middle value and limit.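

In this assay compound 3 yields only a limit and not a number: the limit of > 200 mg/kg in this assay, at which 1 of the 3 values shown sits.

Replacing hydrogen with benzyl on the amine nitrogen had left the number within the scatter, but extending aminomethyl to 3-aminopropyl gives an at least 9.0-fold higher number from compound 2 to compound 3 (0.95 log units; beyond the scatter). Set against the benzyl-bearing amine, the change gives an at least 6.8-fold higher number from compound 1 to compound 3 (0.83 log units; beyond the scatter). The length of the chain linking the amine to the shared core therefore matters on this read-out in a way that the substituent on the amine nitrogen did not, although this rests on a single extended chain.

As far as these compounds go, how far compound 3 lies beyond its limit stays open. Also open, from the compounds shown here alone, is whether the loss would already appear with a 2-aminoethyl chain on the core, and how a carboxylic acid in place of the amine would behave.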